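A few compounds are considered here, and "the series" means these few. Any claim that something is new, unique, unknown or untested is made for them only; others in the source may bear on it.

For the measured compounds named here, compound 2 `CN(C(=O)NC(=O)c1ccccc1F)c1nc(C(F)(F)F)c(C(=O)N/N=C/c2cccc(C(F)(F)F)c2)s1` gives 19.1 ug/mL in a functional assay on HeLa cells (Homo sapiens) for inhibition, read by MTT assay, with a stated time of 72 h (on this read-out higher numbers stand for weaker inhibition and lower numbers for stronger inhibition), the highest of the two numbers so far. Compound 1 `CN(C(=O)NC(=O)c1ccc(C(F)(F)F)cc1)c1nc(C(F)(F)F)c(C(=O)N/N=C/c2cccc(C(F)(F)F)c2)s1`, which bears 4-(trifluoromethyl)phenyl on the same carbonyl carbon, gives 6.2 ug/mL; the step of a 3.1-fold higher number from compound 1 to compound 2 (0.49 log units; beyond the scatter) is the only one measured. Compound 3 `CN(C(=O)NC(=O)c1cccc(C(F)(F)F)c1)c1nc(C(F)(F)F)c(C(=O)N/N=C/c2cccc(C(F)(F)F)c2)s1` differs from compound 2 by 3-(trifluoromethyl)phenyl in place of 2-fluorophenyl on a carbonyl carbon. That step brings back a trifluoromethylphenyl group on the carbonyl carbon, so a move back toward compound 1 is expected, of a size beyond the scatter, a 2.4-fold lower number from compound 2 to compound 3 (0.38 log units; beyond the scatter). Compound 3 is therefore estimated at 8 ug/mL, within 3.5 ug/mL to 18 ug/mL.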

Compound 3, half-maximal inhibitory concentration: 4.81 ug/mL
For compound 3 the middle estimate is 1.7-fold (0.22 log units) above the measured one, within the range that was stated.
By their numbers in this assay, from the lowest: compounds 3 and 1 (each within the scatter of the next); then compound 2.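

On the carbonyl carbon, 3-(trifluoromethyl)phenyl in place of 2-fluorophenyl gives a 4.0-fold lower number from compound 2 to compound 3 (0.60 log units; beyond the scatter) in this assay and so matches the direction of the earlier step. Exchanging 4-(trifluoromethyl)phenyl for 3-(trifluoromethyl)phenyl gives a 1.3-fold lower number from compound 1 to compound 3 (0.11 log units; within the scatter) and so does not separate these two groups. No supporting evidence bears on the reason for these results. With 2-fluorophenyl as the only comparator, the change of substituent and the change of its place on the ring cannot be separated. As far as these compounds go, whether an amine or a carboxylic acid on this phenyl ring would fit the same trend remains open.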